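A Single Ring Exchange Measured in the Solubility Assay

The source may hold more compounds than are shown below. What is called first, only, known or untested is meant among the compounds shown, and "the series" means these compounds.

For the measured compounds named here, compound 1 `O=C(N/N=C/c1ccccc1O)c1cc(-c2ccc(Cl)cc2)nn1Cc1ccc(Cl)nc1` is the only compound here with a number in a physicochemical assay on A549 cells for solubility, read by microscopy, with a stated time of 24 h (on this read-out higher numbers stand for weaker inhibition and lower numbers for stronger inhibition), where compound 1 gives 500 nM. Compound 2 `COc1ccc(/C=N/NC(=O)c2cc(-c3ccc(Cl)cc3)nn2Cc2ccc(Cl)nc2)cc1` has no result in this assay; its entry reads "not determined" (no result reported). Compound 3 `CC(C)(C)c1ccc(Cn2nc(-c3ccc(Cl)cc3)cc2C(=O)N/N=C/c2ccccc2O)cc1` differs from compound 1 by 4-(tert-butyl)phenyl in place of 6-chloropyridin-3-yl on a saturated chain carbon bound to an aromatic nitrogen. Going by the values given here, with no step between two measured compounds available, the data give no guide to the size of this change. The step of a 1.2-fold higher number from compound 1 to compound 3 (0.08 log units; within the scatter) is expected to be small, within the usual scatter or barely beyond it in either direction. Compound 3 is therefore estimated at 600 nM, with a range from 200 nM to 2000 nM.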

Compound 3, half-maximal inhibitory concentration: 430 nM
For compound 3 the middle estimate is 1.4-fold (0.14 log units) above the measured one, within the range that was stated.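

In this assay, for the compounds shown here, the exchange of (6-chloropyridin-3-yl)methyl for 4-(tert-butyl)benzyl gives a 1.2-fold lower number from compound 1 to compound 3 (0.07 log units; within the scatter) and provides the first measured step at this place. A ring of carbon only, without the hetero atom or the chlorine, can therefore stand on this saturated chain carbon with the numbers of the two compounds remaining within the scatter. No measurement shown offers an explanation for this result. Going by these compounds, it remains open what an amine or a carboxylic acid in place of these aromatic groups would give at this place.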